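Pyrimidin-4-yl in Place of the Ketone Aryl Group of Compound 2

The source may hold more compounds than are shown below. What is called first, only, known or untested is meant among the compounds shown, and "the series" means these compounds.

Measured so far:
Compound 1 `O=C(CCCC[S+]([O-])Cc1ccccc1)c1ncc(-c2ccccn2)o1` gives 2500 nM in an assay on isolated protein for inhibition of Fatty-acid amide hydrolase 1 (Homo sapiens); a higher number here means a weaker inhibitor, a lower number a stronger inhibitor.
Compound 2 `CCCCCCCC/C=C\CCCCCCC(=O)c1nc2ncccc2o1` gives 2.3 nM in this assay.

Compound 2 stands lowest of the two numbers. Its nearest neighbour is compound 1, whose number is far higher, and that gap lies well beyond the usual scatter of repeated measurements. Compound 2 is therefore the stronger inhibitor of the two shown.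

The unmeasured compound 3 `CCCCCCCC/C=C\CCCCCCC(=O)c1ccncn1` keeps the long unsaturated chain and the carbonyl of compound 2 and alters only what sits on the carbonyl carbon: a group of 6 heavy atoms (4 carbon, 2 nitrogen; one six-membered aromatic ring with 2 hetero atoms) in place of a group of 9 heavy atoms (6 carbon, 2 nitrogen, 1 oxygen; one five-membered aromatic ring with 2 hetero atoms, one six-membered aromatic ring with 1 hetero atom), on a carbonyl carbon. The other neighbour of that carbonyl carbon, a saturated chain carbon, is unchanged.

Among the compounds with values here, no measured pair traces this change, so the expectation rests on compound 2 alone and on the size of the group that leaves. The step from compound 2 to compound 3 is expected to raise the number in this assay by a margin beyond the scatter, a 130-fold higher number from compound 2 to compound 3 (2.12 log units; beyond the scatter). Compound 3 is accordingly estimated at 300 nM in this assay, with a likely range from 40 nM to 3000 nM.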

Compound 3, inhibition constant: 110 nM
For compound 3 the middle estimate is 2.7-fold (0.44 log units) above the measured one; measured number inside the range.
By their numbers in this assay, from the lowest: compound 2; then compound 3; then compound 1.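

Within the data shown here, with the long unsaturated chain and the carbonyl held constant, this is the first direct reading of the group on the carbonyl carbon: in this assay, placing pyrimidin-4-yl there in place of the group of 9 heavy atoms gives a 48-fold higher number from compound 2 to compound 3 (1.68 log units; beyond the scatter) and counts as a large step. Inhibition at this place therefore depends strongly on which aromatic group is attached, yet the smaller group with its single six-membered aromatic ring does not abolish it, since compound 3 still gives 110 nM in this assay. Nothing at hand explains the size of this step.

This single exchange alters ring number, heavy-atom count and hetero atoms together, so it leaves open which of these differences carries the step, and whether a phenyl or a pyridin-2-yl group on the same carbonyl carbon would fall nearer to compound 2 or to compound 3. From the compounds shown here alone, it is also open whether the step would keep its size if a shorter saturated chain replaced the long unsaturated chain.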